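From pyridin-4-yl to 2-(pyridin-2-yl)ethynyl: cytotoxicity notes

The compounds below may be only part of what the source reports. "The series", "measured", "known", "first", "only" and "open" are said of these compounds alone.

Compound 1 `CNC(=O)[C@@H](NC(=O)[C@@](O)(CCCN(Cc1ccc(-c2cccnc2)cc1)NC(=O)[C@@H](NC(=O)OC)C(C)(C)C)Cc1ccccc1)C(C)(C)C` and compound 2 `CNC(=O)[C@@H](NC(=O)[C@@](O)(CCCN(Cc1ccc(-c2ccncc2)cc1)NC(=O)[C@@H](NC(=O)OC)C(C)(C)C)Cc1ccccc1)C(C)(C)C` share a core and have both been tested in an ADME assay on MT4 cells (Homo sapiens) for cytotoxicity, read by XTT assay, with a stated time of 5 days (on this read-out higher numbers stand for lower toxicity in this test and lower numbers for higher toxicity in this test), so far. Compound 1 gives > 50000 nM as a limit. Compound 2 gives > 50000 nM as a limit too, so it stands without an actual number. Among the compounds with values here, the only measured step is a step that the two limits leave unreadable from compound 1 to compound 2 and it has no readable size. The evidence on the series is the limit of > 50000 nM in this assay, at which 2 of the 2 values shown sit, and nothing more.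

Compound 3 `CNC(=O)[C@@H](NC(=O)[C@@](O)(CCCN(Cc1ccc(C#Cc2ccccn2)cc1)NC(=O)[C@@H](NC(=O)OC)C(C)(C)C)Cc1ccccc1)C(C)(C)C` differs from compound 2 by 2-(pyridin-2-yl)ethynyl in place of pyridin-4-yl on an aromatic carbon as 2-(pyridin-2-yl)ethynyl in place of pyridin-4-yl on an aromatic carbon. Within the data shown here, no measured step involves a triple bond, so no direction can be read from the data. The expectation rests on the limit of compound 2 at > 50000 nM alone. The expected change is a number no higher from compound 2 to compound 3 (the limit leaves the size open) and none beyond the scatter is expected. Compound 3 is estimated at 50000 nM in this assay with an expected range of 20000 nM to 100000 nM around it.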

Compound 3, half-maximal cytotoxic concentration: > 50000 nM
Compound 3: only a limit was reported; the forecaster's own chance of this, stated with the estimate: 75%; the middle value lies on the limit itself.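

Within the data shown here, compound 1, compound 2 and compound 3 each give only a limit in this assay, so no step among them can be read. The compounds shown leave open where the actual half-maximal cytotoxic concentrations lie, and whether exchanging pyridin-3-yl, pyridin-4-yl and 2-(pyridin-2-yl)ethynyl changes them at all.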